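The source may report more compounds than this note shows. Statements on the series, on what has been measured and on what is new or still open speak of the compounds shown alone.

Measured compounds:
- compound 1 `O=S(=O)(c1cc(Cl)cc(Cl)c1)c1cnc2c(F)cccc2c1-c1cccc(F)c1` gives 1.08 mL/min in an ADME assay on microsomes from liver (Homo sapiens) for metabolic stability, tested at 2.5 uM; on this read-out higher numbers stand for fast clearance and lower numbers for slow clearance
- compound 2 `O=S(=O)(c1ccc(F)c(Cl)c1)c1cnc2c(F)cccc2c1-c1cccc(F)c1` gives 1.23 mL/min in this assay

Going by the values given here, compound 2 holds the higher of the two numbers on this read-out, with compound 1 its only neighbour; the single step so far, a 1.1-fold higher number from compound 1 to compound 2 (0.06 log units; within the scatter), does not separate the two compounds. Compound 3 `O=S(=O)(c1cc(F)cc(F)c1)c1cnc2c(F)cccc2c1-c1cccc(F)c1` is the next member of the series and is not yet measured.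

The change from compound 2 to compound 3 is 3,5-difluorophenyl in place of 3-chloro-4-fluorophenyl on a sulfonyl sulfur

Among the compounds with values here, the only measured step that bears on this change is the halogen swap on the same sulfonyl sulfur, a 1.1-fold higher number from compound 1 to compound 2 (0.06 log units; within the scatter), which stayed within the scatter. On that basis no step beyond the scatter is expected for compound 3 in this assay; the expected step is a 1.1-fold lower number from compound 2 to compound 3 (0.05 log units; within the scatter). Compound 3 is therefore estimated at 1.1 mL/min, with a range from 0.6 mL/min to 2.2 mL/min.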

Compound 3, intrinsic clearance in a liver preparation (reported as CLH), per the amount of preparation that the assay uses: 1.18 mL/min
The estimate for compound 3 lay 1.1-fold (0.03 log units) below the measured number, and the stated range covers the measured number.
By their numbers in this assay, from the lowest: compounds 1, 3 and 2 (each within the scatter of the next).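

In this assay the change to 3,5-difluorophenyl from 3-chloro-4-fluorophenyl on a sulfonyl sulfur gives (a 1.0-fold lower number from compound 2 to compound 3 (0.02 log units; within the scatter)), and the change to the same group from 3,5-dichlorophenyl gives (a 1.1-fold higher number from compound 1 to compound 3 (0.04 log units; within the scatter)). Compound 3 thus carries fluorine alone on this ring, and taking chlorine off the ring entirely leaves the number within the scatter of both earlier compounds, which the chlorine-bearing pair alone could not show. No supporting data bear on why the three numbers stay together.

On these data alone, whether an amine or a carboxylic acid on this ring, or a cyclohexyl group in place of the phenyl, would move the number beyond the scatter stays open. As far as these compounds go, the rest of the structure is the same in all three compounds, so the part it plays in this read-out also stays open.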